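The source may hold more compounds than are shown below. What is called first, only, known or untested is meant among the compounds shown, and "the series" means these compounds.

Measured so far in a functional assay on a cell-free system (Platelet, plasma, Oryctolagus cuniculus) for inhibition, with a stated time of 5 min (a higher number here means a weaker inhibitor, a lower number a stronger inhibitor), as follows
Compound 1 `COC(=O)c1ccc(OCc2nc(C)c(C)nc2C)c(OC)c1` gives > 2000000 nM as a limit
Compound 2 `Cc1nc(C)c(COc2ccccc2C(=O)O)nc1C` gives 400000 nM as a number

Compound 1 stands at the limit of > 2000000 nM in this assay, at which 1 of the 2 values shown sits, and so has no number. Compound 3 `COc1cc(C(=O)O)ccc1OCc1nc(C)c(C)nc1C` differs from it by hydrogen in place of methyl on an oxygen next to a carbonyl group, with hydrogen in place of methyl on an oxygen next to a carbonyl group, so that methoxycarbonyl becomes carboxy. For the measured compounds named here, no measured step covers this change. Going by the values given here, the only guide is compound 2, also a carboxy compound, at 400000 nM in this assay. On that basis, a shift towards stronger inhibition, beyond the scatter, is expected, and an at least 4.0-fold lower number from compound 1 to compound 3 (0.60 log units; beyond the scatter) is the estimated step. A result at the limit remains possible. For compound 3 the estimated value is 500000 nM, with an expected range from 150000 nM to 1600000 nM in this assay.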

Compound 3, half-maximal inhibitory concentration: > 2000000 nM
Compound 3: a limit, no number; the forecaster's own chance of this, stated with the estimate: 25%; at least 4.0-fold (0.60 log units) between middle value and limit.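

No step can be read from compound 1 to compound 3 in this assay, as both results are limits and neither gives a number: the limit of > 2000000 nM in this assay, at which 2 of the 3 values shown sit.

The compounds shown leave open whether methoxycarbonyl to carboxy on the core of compound 1 changes inhibition at all.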